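The compounds below may be only part of what the source reports. "The series", "measured", "known", "first", "only" and "open" are said of these compounds alone.

Measured so far:
compound 1, `Cc1cc(Cl)ccc1OC(C)C(=O)N/N=C/c1ccccc1OC(F)(F)F`, "not active" (no number reported)
compound 2, `Cc1cc(Cl)ccc1OC(C)(C)C(=O)N/N=C/c1ccccc1OC(F)(F)F`, > 100000 nM

In an ADME assay on cells for inhibition of anoctamin-2 (Homo sapiens), read by fluorescence, with a stated time of 20 min (on this read-out lower numbers stand for stronger inhibition and higher numbers for weaker inhibition), compound 1 is reported only as "not active" (no number reported), without a number. Compound 2 sits at a limit of the assay, > 100000 nM, the point marked as the limit of > 100000 nM in this assay, at which 1 of the 2 values shown sits. Compound 1 therefore has no position on a scale beyond having failed to register. Compound 3, `Cc1cc(Cl)ccc1OCC(=O)N/N=C/c1ccccc1OC(F)(F)F`, differs from compound 1 by hydrogen in place of methyl on a saturated chain carbon bound to a carbonyl carbon and an oxygen on an aromatic ring. Among the compounds with values here, with no measured step to draw on, no shift beyond the usual scatter is expected in this assay in either direction. Compound 3 is expected to give about 150000 nM, estimated between 50000 nM and 500000 nM, most likely again reported only as a limit.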

Compound 3, half-maximal inhibitory concentration: "not active" (no number reported)
Compound 3 has no reported number here, and the estimate cannot be compared.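

In this assay, within the data shown here, compound 1 gives "not active" (no number reported) and compound 3 gives "not active" (no number reported), so no step between them can be read. The compounds shown leave open whether exchanging methyl for hydrogen on this saturated chain carbon changes inhibition at all.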